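A few compounds are considered here, and "the series" means these few. Any claim that something is new, unique, unknown or untested is made for them only; others in the source may bear on it.

Compound 1 `CC/C=C/CC(=O)OCC1COCCOCCOCCOCCOCCO1` joins the shared core through an ester to a short unsaturated chain. In a functional assay on HBL-100 cells (Homo sapiens) for inhibition, read by sulforhodamine B assay, with a stated time of 48 h (on this read-out lower numbers stand for stronger inhibition of growth and higher numbers for weaker inhibition of growth), compound 1 gives only a limit, > 100000 nM, not a number. Two further compounds keep the ester link to the core. Compound 2 `O=C(OCC1COCCOCCOCCOCCOCCO1)c1cccc(-c2ccc(Br)cc2)c1` carries a rigid two-ring aromatic acid, and in this assay compound 2 gives 6400 nM. Compound 3 `O=C(CCCCC1CCCCC1)OCC1COCCOCCOCCO1` sits on a shorter version of the core and carries a flexible chain ending in a saturated ring; in this assay compound 3 gives only a limit, > 100000 nM. Compound 1 therefore stands at the limit of > 100000 nM in this assay, at which 2 of the 3 values shown sit, and compound 2 is the only one of the three that yields a number.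

Compound 4 `O=C(CCCCc1ccccc1)OCC1COCCOCCOCCOCCOCCO1` has not yet been measured in this assay. It differs from compound 1 by 3-phenylpropyl in place of but-1-en-1-yl on a saturated chain carbon bound to a carbonyl carbon. Compound 2 shows that an aromatic group can bring the value into the measurable range, but there the aromatic ring sits on the carbonyl carbon itself, whereas compound 4 keeps a flexible chain, much as compound 3 does. On that basis a step from compound 1 to compound 4 of about an at least 1.6-fold lower number from compound 1 to compound 4 (0.22 log units; that floor lies within the scatter) is expected, toward stronger inhibition but modest enough that a limit remains quite possible. Compound 4 is estimated at 60000 nM, between 15000 nM and 150000 nM.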

Compound 4, concentration for 50% growth inhibition: 69000 nM
For compound 4 the middle estimate is 1.2-fold (0.06 log units) below the measured one; measured number inside the range.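

At the saturated chain carbon bound to a carbonyl carbon, putting 3-phenylpropyl in place of but-1-en-1-yl gives an at least 1.4-fold lower number from compound 1 to compound 4 (0.16 log units; that floor lies within the scatter) in this assay, so this floor alone does not establish a real gain. The new information is that a number can be read with a flexible chain at this position: previously only compound 2, whose aromatic ring sits on the carbonyl carbon itself, gave one, and now compound 4 gives 69000 nM. Compound 1 gives > 100000 nM, which is a limit and not a number, and one other compound shown stands in the same place: the limit of > 100000 nM in this assay, at which 2 of the 4 values shown sit.

The compounds shown leave open which part of this change matters, since the phenyl ring, the longer chain and the loss of the double bond all arrive together in this one step. They also say nothing about how an amine or a carboxylic acid on the phenyl ring of compound 4 would read, or how a plain saturated chain of the same length without a ring would compare.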